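From a charged chain end to an uncharged one

The source may hold more compounds than are shown below. What is called first, only, known or untested is meant among the compounds shown, and "the series" means these compounds.

Compound 3 `Cc1c(C)c2c(c(C)c1O)CCC(C)(CC[S+](C)C)O2` shares its core with compound 1 `Cc1c(C)c2c(c(C)c1O)CCC(C)(CC[N+](C)(C)C)O2` and compound 2 `Cc1c(C)c2c(c(C)c1O)CC[C@@](C)(CC[S+](C)C)O2`. In a functional assay (brain) for inhibition, with Rattus norvegicus as the target (on this read-out higher numbers stand for weaker inhibition and lower numbers for stronger inhibition), compound 3 gives 2000 nM, compound 2 gives 2000 nM and compound 1 gives 2600 nM; compound 3 stands level with compound 2, the pair together at the low end of the three numbers. The step of no change at the digits printed from compound 2 to compound 3 (within the scatter) rests only on (the fact that one of compounds 2 and 3 is drawn with a defined configuration and the other without, at the place where they differ). Within the data shown here, the step of a 1.3-fold lower number from compound 1 to compound 3 (0.11 log units; within the scatter) is the one earlier swap of the chain end. Compound 4 `Cc1c(C)c2c(c(C)c1O)CCC(C)(CC(=O)[N-][N+](C)(C)C)O2` differs from compound 3 by a group of 7 heavy atoms (4 carbon, 2 nitrogen, 1 oxygen; no ring) in place of a group of 4 heavy atoms (3 carbon, 1 sulfur; no ring), on a saturated chain carbon bound to a saturated ring carbon. Among the measured compounds shown here, no measured step trades a charged group for an uncharged one, so the expectation is loose. Compound 4 is expected to give 3000 nM, between 1000 nM and 10000 nM. The expected step is a 1.5-fold higher number from compound 3 to compound 4 (0.18 log units; within the scatter).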

Compound 4, half-maximal inhibitory concentration: 6000 nM
The estimate for compound 4 lay 2.0-fold (0.30 log units) below the measured number; the measured number falls inside the stated range.
By their numbers in this assay, from the lowest: compounds 2, 3 and 1 (each within the scatter of the next); then compound 4.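

The earlier swap of chain ends stayed within the scatter, but this larger change goes beyond it, with inhibition modestly weaker: the data give a 3.0-fold higher number from compound 3 to compound 4 (0.48 log units; beyond the scatter) and a 2.3-fold higher number from compound 1 to compound 4 (0.36 log units; beyond the scatter). The one available structural note concerns only the drawn configuration of compounds 2 and 3, so nothing here explains this rise.

The change alters the size of the chain end, adds a carbonyl and removes the net charge all at once, and these compounds cannot separate those changes. On these data alone, how a carboxylic acid, an amine or a longer chain would behave at this place remains open.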